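Swapping the Sugar's Partner on a Galloyl Glucoside

The source may hold more compounds than are shown below. What is called first, only, known or untested is meant among the compounds shown, and "the series" means these compounds.

Measured so far:
Compound 1 `CC1=CC[C@@H](C(C)(C)O[C@@H]2O[C@H](COC(=O)c3cc(O)c(O)c(O)c3)[C@@H](O)[C@H](O)[C@H]2O)CC1`: 14.8%
Compound 2 `COc1cc(CC(CO)O[C@@H]2O[C@H](COC(=O)c3cc(O)c(O)c(O)c3)[C@@H](O)[C@H](O)[C@H]2O)ccc1O`: 17.7%

In a functional assay, read by spectrophotometry, with a stated time of 30 min, tested at 2.5 uM (a lower number here means a weaker effect, a higher number a stronger effect of the compound at the concentration tested), compound 1 gives 14.8%. Compound 2 gives 17.7%, and the two numbers lie within the usual scatter of each other, so neither compound stands apart from the other on this pair alone.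

Compound 3 `C=CCc1ccc(O[C@@H]2O[C@H](COC(=O)c3cc(O)c(O)c(O)c3)[C@@H](O)[C@H](O)[C@H]2O)c(OC)c1` has not yet been measured. It differs from compound 1 in one place: 4-allyl-2-methoxyphenyl in place of 1-methyl-1-(4-methylcyclohex-3-en-1-yl)ethyl on an oxygen on a saturated carbon. Among the measured compounds shown here, no two measured compounds differ from each other in a single place, so the size of this step cannot be read from a measured one. For the measured compounds named here, the only other number available is that of compound 2, which gives 17.7%, a number within the scatter of compound 1. The step of a number 3.2 percentage points higher from compound 1 to compound 3 (within the scatter) is therefore expected to be small, upward if anything, and not beyond the scatter. Compound 3 is estimated at 18%, with a range from 8% to 30%.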

Compound 3, a percentage reported as activity, at one concentration (the size of the read-out at that concentration, not a potency): 15%
The estimate for compound 3 lay 3 percentage points above the measured number, and the stated range covers the measured number.
By their numbers in this assay, from the lowest: compounds 1, 3 and 2 (each within the scatter of the next).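

In this assay, 4-allyl-2-methoxyphenyl in place of 1-methyl-1-(4-methylcyclohex-3-en-1-yl)ethyl gives a number 0.2 percentage points higher from compound 1 to compound 3 (within the scatter). At this position, on an oxygen on a saturated carbon, a six-membered aromatic ring of carbon only and a hydrogen-bond acceptor can therefore enter where a six-membered non-aromatic ring of carbon only stood, with no difference the measurement can separate from scatter. No separate measurement bears on this result.

Going by these compounds, it remains open whether any group at this position can move the read-out beyond the scatter, for example a partner carrying an amine or a carboxylic acid. Among the compounds shown here, with only this one step, the result also cannot say whether the same swap would behave alike on a different core.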